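Open chains in place of a ring on the shared core

The source may report more compounds than this note shows. Statements on the series, on what has been measured and on what is new or still open speak of the compounds shown alone.

Three measured compounds share one core and differ only in the group carried on a single aromatic carbon. Compound 1 `CCCCCCCCCCc1ccc(-c2noc([C@H]3CCCN3)n2)cc1` gives 12% in an assay on HeLa cells for inhibition of sphingosine-1-phosphate transporter SPNS2 (Mus musculus), read by LC-MS, tested at 2 uM; a higher number here means more inhibition at the concentration tested (going by the name of the read-out), a lower number less inhibition. Compound 2 `CCCCCCCCCCc1ccc(-c2noc([C@@H]3CCCN3)n2)cc1` gives 21% in this assay; the step of a number 9 percentage points higher from compound 1 to compound 2 (within the scatter) rests on (the fact that compounds 1 and 2 differ only in the configuration as drawn). Compound 3 `CCCCCCCCCCc1ccc(-c2noc(C(Cl)CCN)n2)cc1` gives 5%, the lowest of the three numbers, although its gap to compound 1 lies within the scatter and only its gap to compound 2 lies beyond it: a number 7 percentage points lower from compound 1 to compound 3 (within the scatter) and a number 16 percentage points lower from compound 2 to compound 3 (beyond the scatter).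

Compound 4 `CCCCCCCCCCc1ccc(-c2noc([C@@H](N)CCCN)n2)cc1` differs from compound 3 by a group of 6 heavy atoms (4 carbon, 2 nitrogen; no ring) in place of a group of 5 heavy atoms (3 carbon, 1 nitrogen, 1 chlorine; no ring), on an aromatic carbon. Among the compounds with values here, no measured step exchanges one open chain for another; the two steps that reach compound 3 replace the five-membered ring with the chloro chain, and both were small to modest. Those steps suggest that changes at this position move the read-out by modest amounts, so the expected step is small and its direction uncertain. Compound 4 is therefore expected to give about 15%, between 0% and 35%, which means an expected step of a number 10 percentage points higher from compound 3 to compound 4 (within the scatter).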

Compound 4, a percentage reported as inhibition, at one concentration (the size of the read-out at that concentration, not a potency): 40%
Compound 4: the middle estimate sits 25 percentage points below what was measured; measured number outside the range, above it.
By their numbers in this assay, from the lowest: compounds 3, 1 and 2 (each within the scatter of the next, the first and the last beyond it); then compound 4.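

Replacing the ring with an open chain need not lower the number in this assay: 1,4-diaminobutyl gives a number 28 percentage points higher from compound 1 to compound 4 (beyond the scatter) and a number 19 percentage points higher from compound 2 to compound 4 (beyond the scatter) on the shared core. Two open chains can also lie far apart at this position, with a number 35 percentage points higher from compound 3 to compound 4 (beyond the scatter) as the largest step seen so far. An open chain can therefore go either way against the ring, since compound 3 lies below compound 2 while compound 4 lies above it.

Nothing shown gives a reason for this rise. On these data alone, it remains open whether the gain depends on the amine nearest the aromatic ring, the amine at the chain end or the defined stereocentre, and how a shorter diamine chain or a carboxylic acid would read here.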